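Replacing 3-Carboxypropyl with (Piperidin-1-yl)carbonyl

The source may hold more compounds than are shown below. What is called first, only, known or untested is meant among the compounds shown, and "the series" means these compounds.

Three compounds have been measured in an assay on HEK293 cells for binding affinity to Substance-K receptor (Rattus norvegicus), read by FRET, tested at 10 uM; on this read-out higher numbers stand for more inhibition at the one concentration tested (going by the name of the read-out) and lower numbers for less inhibition:

Compound 1 `N#CCN(Cc1ccc(I)cc1)Cc1ccc2ccccc2c1` gives 0%
Compound 2 `CCOC(=O)CCCCN(Cc1ccccc1)Cc1ccc2ccccc2c1` gives 0%
Compound 3 `O=C(O)CCCCN(Cc1ccccc1)Cc1ccc2ccccc2c1` gives 0%

Compound 3 stands level with compounds 1 and 2 at the digits shown, and the one measured step, no change at the digits printed from compound 2 to compound 3 (within the scatter), lies within the scatter. None of the three shows any measurable inhibition.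

Compound 4 `O=C(CN(Cc1ccccc1)Cc1ccc2ccccc2c1)N1CCCCC1` is not yet measured. It differs from compound 3 in one place: (piperidin-1-yl)carbonyl in place of 3-carboxypropyl on a saturated chain carbon bound to an amine nitrogen. For the measured compounds named here, no measured step touches this kind of change; the only step on record concerns the ester-to-acid change and was flat. There is thus nothing in the data that points to a rise or a fall, and the three measured values all sit at the floor of the read-out. The step is expected to stay within the scatter, as a number 5 percentage points higher from compound 3 to compound 4 (within the scatter). Compound 4 is therefore estimated to give 5%, with a range from -10% to 25%.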

Compound 4, a percentage reported as inhibition, at one concentration (the size of the read-out at that concentration, not a potency): 0%
Beside the measured number, compound 4's estimate is 5 percentage points above it; the measured number falls inside the stated range.
By their numbers in this assay, from the lowest: compounds 1, 2, 3 and 4 (each within the scatter of the next).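

Placing (piperidin-1-yl)carbonyl on a saturated chain carbon bound to an amine nitrogen leaves this assay flat, with no change at the digits printed from compound 3 to compound 4 (within the scatter) and with no change at the digits printed from compound 2 to compound 4 (within the scatter) when the ester is the starting point. Until now, only the ester-to-acid change had been tested here; the result extends the flat outcome to a change that brings in a six-membered non-aromatic ring, removes the acid's hydrogen-bond donor and replaces 4-carboxybutyl with ((piperidin-1-yl)carbonyl)methyl. Nothing available explains why the read-out does not move.

Still open, as far as these compounds go, is whether a primary amine, a morpholine amide or a tetrazole at this place would produce any inhibition. With every value at the same level, the compounds also cannot rank these groups against one another.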